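Amino for ethynyl on a phenylpropanoic acid agonist

This account rests on a few compounds, and the source may have more. Where it says the series, first, only, none or still open, it means among the compounds named here.

Of the compounds shown here, three sharing one core have been measured in an in vitro functional assay on 1321-N1 cells for agonist activity at Free fatty acid receptor 1 (Homo sapiens), read by fluorescence; a lower number here means that less compound is needed, a higher number that more compound is needed for the effect. Compound 1 `C#Cc1cccc(C#Cc2ccc(CCC(=O)O)cc2)c1` gives 155 nM, the highest of the three numbers. Compound 2 `Cc1cccc(C#Cc2ccc(CCC(=O)O)cc2)c1C` gives 87.1 nM, a value that lies within the scatter of compound 1. Compound 3 `Cc1cc(C)cc(C#Cc2ccc(CCC(=O)O)cc2)c1` gives 74.1 nM, which stands beyond the scatter from compound 1, so compound 3 needs less compound for the effect than compound 1 does. Going by the values given here, none of the three pairs differs in only one place, so no single structural step between measured compounds can be isolated.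

Compound 4 `Nc1cccc(C#Cc2ccc(CCC(=O)O)cc2)c1` has not yet been measured in this assay. It differs from compound 1 by amino in place of ethynyl on an aromatic carbon. Among the compounds with values here, nothing among the measured compounds tells how this particular exchange moves the read-out, since every change seen so far keeps a carbon group on the outer ring. An estimate therefore rests only on the spread of the three known values. A step of modest size toward a higher number, meaning more of compound 4 would be needed, is expected, given as a 1.9-fold higher number from compound 1 to compound 4 (0.29 log units; within the scatter). Compound 4 is expected to give about 300 nM, with a range from 100 nM to 900 nM.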

Compound 4, half-maximal effective concentration: 1100 nM
Compound 4: middle estimate off by 3.7-fold (0.56 log units), on the low side, and the stated range ends below it.
By their numbers in this assay, from the lowest: compounds 3, 2 and 1 (each within the scatter of the next, the first and the last beyond it); then compound 4.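

Going by these compounds alone, replacing ethynyl with amino on an aromatic carbon, meta to a large group, gives a 7.1-fold higher number from compound 1 to compound 4 (0.85 log units; beyond the scatter) in this assay; this is the first change in the set confined to a single place, and it lies beyond the scatter. It shows that the read-out at this position depends on the group present: the exchange removes a two-carbon group with a triple bond and brings in a single nitrogen that counts as both a hydrogen-bond donor and acceptor, and more compound is then needed for the effect. Which of these differences matters cannot be told from this pair, and nothing measured on the two groups offers an explanation.

From the compounds shown here alone, it remains open whether the step reflects the loss of ethynyl or the arrival of amino, a question that a hydrogen, a methyl or a hydroxyl at the same place could help to separate. Also open, going by these compounds, is whether the nitrogen itself is tied to the higher number, which an acetamide or a dimethylamino group at this position would test.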